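Swapping a Trifluoromethoxy for an Acetamido Group

The source may hold more compounds than are shown below. What is called first, only, known or untested is meant among the compounds shown, and "the series" means these compounds.

Measured compounds:
Compound 1, `CC(C)(C)c1ccc(C(=O)NCc2ccc(OC(F)(F)F)cc2)cc1`, 160 nM
Compound 2, `Cc1cc(CNC(=O)c2ccc(C(C)(C)C)cc2)ccc1C(=O)O`, 160 nM
Compound 3, `COc1ccc(CNC(=O)c2ccc(C(C)(C)C)cc2)cc1`, 150 nM

In an assay on HeLa cells with Bile acid receptor (Homo sapiens) as the target, read by a luciferase reporter, with a stated time of 24 h (a higher number here means that more compound is needed for the effect, a lower number that less compound is needed), compound 1 gives 160 nM. On the numbers shown it sits level with compound 2 at the digits printed, and the two together give the highest numbers of the three; compound 3 is the furthest from it, yet the step of a 1.1-fold lower number from compound 1 to compound 3 (0.03 log units; within the scatter) is within the scatter. The three compounds share one core and differ only in what sits on the benzylic ring, and all three land within the scatter of one another.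

Compound 4, `CC(=O)Nc1ccc(CNC(=O)c2ccc(C(C)(C)C)cc2)cc1`, has not been measured. It differs from compound 1 as follows: acetamido in place of trifluoromethoxy on an aromatic carbon. For the measured compounds named here, the only measured step that bears on a change at this position, a 1.1-fold lower number from compound 1 to compound 3 (0.03 log units; within the scatter), was within the scatter, and compound 2 shows a third variant at the same place at the same level. Going by the values given here, no measured step involves an acetamido group, so the expectation rests on the flatness seen so far. Compound 4 is therefore expected to show a step of a 1.3-fold higher number from compound 1 to compound 4 (0.10 log units; within the scatter), no larger than the scatter. The estimate for compound 4 is 200 nM, within a range of 80 nM to 600 nM.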

Compound 4, half-maximal effective concentration: 2900 nM
Estimate against measurement, compound 4: 15-fold (1.16 log units) below; measured number above the stated range.
By their numbers in this assay, from the lowest: compounds 3, 1 and 2 (each within the scatter of the next); then compound 4.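

In this assay, for the compounds shown here, this position proves not to be indifferent: the flat picture left by the earlier compounds breaks, with an 18-fold higher number from compound 1 to compound 4 (1.26 log units; beyond the scatter) and with a 19-fold higher number from compound 3 to compound 4 (1.29 log units; beyond the scatter) once acetamido stands on this aromatic carbon. The earlier agreement therefore held only for the groups then compared, and a change at this place, para to a large group, can move the number well beyond the scatter. Nothing available here explains the size of this step.

The compounds shown leave open whether a plain amine or a longer chain such as propanamido on this carbon would stay level with compound 1 or follow compound 4. They also leave open whether the hydrogen-bond donor that enters with acetamido, and that trifluoromethoxy lacks, has any part in the step.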